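The compounds below may be only part of what the source reports. "The series", "measured", "known", "first", "only" and "open" are said of these compounds alone.

Working notes on the series.

Of the compounds shown here, three share the sulfonylated indole carboxamide core and have been measured in an ADME assay on CCRF-CEM cells (Homo sapiens) for cytotoxicity, read by cell counting; a higher number here means that more compound is tolerated, a lower number that less compound is tolerated. Compound 1 `Cc1cc(C)cc(S(=O)(=O)c2c(C(=O)NCc3ccccc3)[nH]c3ccc([N+](=O)[O-])cc23)c1` carries a benzylamino amide and gives 8000 nM. Compound 2 `Cc1cc(C)cc(S(=O)(=O)c2c(C(=O)NCCOc3ccccc3)[nH]c3ccc(Cl)c(F)c23)c1` carries a (2-phenoxyethyl)amino amide on a differently substituted core and gives 11000 nM. Compound 3 `Cc1cc(C)cc(S(=O)(=O)c2c(C(=O)NCCOc3ccccc3)[nH]c3ccc([N+](=O)[O-])cc23)c1` combines the (2-phenoxyethyl)amino amide with the core of compound 1; in this assay compound 3 reaches only a limit, > 500000 nM, and no number. That limit is the point at which the assay stops reporting values (the limit of > 500000 nM in this assay, at which 1 of the 3 values shown sits).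

Going by the values given here, the one step measured within a single core is the change (phenyl in place of phenoxymethyl on a saturated chain carbon bound to an amide-type nitrogen). It produces an at least 62-fold lower number from compound 3 to compound 1 (1.79 log units; beyond the scatter), the true size of which is open because compound 3 sits at the limit (the limit of > 500000 nM in this assay, at which 1 of the 3 values shown sits). The difference between the core of compound 2 and the core of compound 3 is not broken down here; their values stand as shown above, with compound 2 giving a number and compound 3 a limit.

Compound 4 `Cc1cc(C)cc(S(=O)(=O)c2c(C(=O)NCc3ccccc3)[nH]c3ccc(Cl)c(F)c23)c1` has not yet been measured. It differs from compound 2 by phenyl in place of phenoxymethyl on a saturated chain carbon bound to an amide-type nitrogen, the same change that separates compound 3 from compound 1. Compound 1, which carries the benzylamino amide, gives 8000 nM, and compound 2 gives 11000 nM, so the two measured numbers lie close together. For compound 4 in this assay the expectation is a modest downward step, a 2.2-fold lower number from compound 2 to compound 4 (0.34 log units; beyond the scatter), smaller than the measured one, since the measured one starts from a limit and the benzylamino compound 1 already sits near compound 2. The estimate for compound 4 is 5000 nM, between 1500 nM and 20000 nM.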

Compound 4, half-maximal cytotoxic concentration: 15000 nM
Compound 4: middle estimate off by 3.0-fold (0.48 log units), on the low side; measured number inside the range.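

In this assay, phenyl in place of phenoxymethyl on a saturated chain carbon bound to an amide-type nitrogen gives a 1.4-fold higher number from compound 2 to compound 4 (0.13 log units; within the scatter), so on the core of compound 2 this change does not separate the two compounds. On the evidence of the two cores, the change does not carry over as a step of similar size, and the earlier step from the core of compound 1 cannot be used to predict its effect on the core of compound 2: the same change on two cores in this assay, an at least 62-fold lower number (1.79 log units; beyond the scatter) from compound 3 to compound 1 and a 1.4-fold higher number (0.13 log units; within the scatter) from compound 2 to compound 4, at least 85-fold (1.93 log units) apart, beyond the scatter of two such steps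

The comparison rests in part on compound 3, whose > 500000 nM is a limit and not a number, so the earlier step has no exact size, and two cores show neither why the steps differ nor what the change would do on a third core.

The core of compound 1 and the core of compound 2 are not resolved into single changes, which leaves open which core feature goes with the difference between the steps. Also open, on these data alone, is how an amine, a carboxylic acid or a longer chain in place of phenyl or phenoxymethyl on that saturated chain carbon would read on either core.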